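A few compounds are considered here, and "the series" means these few. Any claim that something is new, unique, unknown or untested is made for them only; others in the source may bear on it.

Compound 1 `CC(Sc1nc2c(cnn2C)c(=O)n1-c1ccccc1)c1ccccn1` gives 242 nM in an assay on isolated protein for inhibition of aldehyde dehydrogenase 1A1 (Homo sapiens); on this read-out lower numbers stand for stronger inhibition and higher numbers for weaker inhibition. Compound 2 `CC(Sc1nc2c(cnn2C)c(=O)n1-c1ccccc1)c1cccc(F)c1` gives 151 nM in this assay. Compound 3 `CC(Sc1nc2c(cnn2C)c(=O)n1-c1ccccc1)c1ccccc1` gives 130 nM in this assay.

Compound 3 carries the lowest of the three numbers, yet its separation from the others is small: a 1.9-fold lower number from compound 1 to compound 3 (0.27 log units; within the scatter) and a 1.2-fold lower number from compound 2 to compound 3 (0.07 log units; within the scatter), both within the scatter. Compound 4 `COc1ccc(C(C)Sc2nc3c(cnn3C)c(=O)n2-c2ccccc2)cc1` differs from compound 3 by methoxy in place of hydrogen on an aromatic carbon. For the measured compounds named here, the one measured step that changes a substituent on this aromatic ring is a 1.2-fold lower number from compound 2 to compound 3 (0.07 log units; within the scatter), which stayed within the scatter; no step involving methoxy has been measured. Compound 4 is therefore expected to give 120 nM, with a range from 50 nM to 290 nM. This corresponds to an expected step of a 1.1-fold lower number from compound 3 to compound 4 (0.03 log units; within the scatter), not beyond the scatter.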

Compound 4, half-maximal inhibitory concentration: 352 nM
Beside the measured number, compound 4's estimate is 2.9-fold (0.47 log units) below it, and the stated range ends below it.
By their numbers in this assay, from the lowest: compounds 3, 2, 1 and 4 (each within the scatter of the next, the first and the last beyond it).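

In this assay, methoxy para to a large group gives a change on this ring that passes the scatter, a 2.7-fold higher number from compound 3 to compound 4 (0.43 log units; beyond the scatter), so this ring position does respond to what it carries. The exchange of 3-fluorophenyl for 4-methoxyphenyl also passes it, a 2.3-fold higher number from compound 2 to compound 4 (0.37 log units; beyond the scatter), while the exchange of pyridin-2-yl for 4-methoxyphenyl stays within it, a 1.5-fold higher number from compound 1 to compound 4 (0.16 log units; within the scatter). Nothing available here gives a reason for these steps.

The compounds shown leave open whether the higher number is particular to methoxy. A chloro, a hydroxy or an ethoxy at this same place could settle that.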